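A few compounds are considered here, and "the series" means these few. Any claim that something is new, unique, unknown or untested is made for them only; others in the source may bear on it.

Measured so far in a functional assay on cells (Mast cell, Rattus norvegicus, strain Wistar) for activation, read by fluorescence, with a stated time of 15 min; on this read-out higher numbers stand for an effect only at larger amounts of compound and lower numbers for an effect already at smaller amounts:
compound 1 `CCCCCCCCCCCCCCCCCC(=O)OC[C@@H](O)COP(=O)(O)O[C@@H](C)[C@H](N)C(=O)O` gives 2000 nM
compound 2 `CCCCCCCCCCCCCCCCCC(=O)OCCCOP(=O)(O)O[C@H](C)[C@H](N)C(=O)O` gives 100 nM
compound 3 `CCCCCCCCCCCCCCCC(=O)OCCCOP(=O)(O)O[C@H](C)[C@H](N)C(=O)O` gives 60 nM

Compound 3 stands lowest of the three numbers in this assay; compound 2 sits within the scatter of it, a 1.7-fold lower number from compound 2 to compound 3 (0.22 log units; within the scatter), while compound 1 sits well beyond it. Compound 4 `CCCCCCCCCCCCCCCC(=O)OC[C@@H](O)COP(=O)(O)O[C@H](C)[C@H](N)C(=O)O` differs from compound 3 by hydroxy in place of hydrogen on a saturated chain carbon bound to two saturated chain carbons. For the measured compounds named here, no measured step isolates this change. Going by the values given here, the only guidance is that compound 1, which also carries a hydroxy but differs from compound 2 in other respects too, gives a much higher number than compound 2. Because of that gap between 2000 nM for compound 1 and 100 nM for compound 2, a higher number is expected for compound 4, a 10-fold higher number from compound 3 to compound 4 (1.00 log units; beyond the scatter), with wide uncertainty. Compound 4 is estimated at 600 nM, range 150 nM to 3000 nM.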

Compound 4, half-maximal effective concentration: 40 nM
Estimate against measurement, compound 4: 15-fold (1.18 log units) above, outside the stated range (below it).
By their numbers in this assay, from the lowest: compounds 4, 3 and 2 (each within the scatter of the next, the first and the last beyond it); then compound 1.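

In this assay, hydroxy in place of hydrogen on a saturated chain carbon bound to two saturated chain carbons gives a 1.5-fold lower number from compound 3 to compound 4 (0.18 log units; within the scatter). For the compounds shown here, this is the first reading of that change alone, and it shows the position takes a hydroxy with no step beyond the scatter; compound 1 differs from compound 2 in more than one place and could not show this. Nothing at hand explains the result. Open, from the compounds shown here alone, is whether a methoxy or an amine on this carbon also stays within the scatter of compound 3. Also open, going by these compounds, is how the opposite configuration of the hydroxy-bearing carbon reads on its own.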